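Series notes: from compound 2 to compound 3

This account rests on a few compounds, and the source may have more. Where it says the series, first, only, none or still open, it means among the compounds named here.

Measured in a functional assay on A549 cells (Homo sapiens) for antiproliferative activity, read by sulforhodamine B assay, with a stated time of 48 h (on this read-out lower numbers stand for stronger inhibition and higher numbers for weaker inhibition), so far:
- compound 1 `COc1ccc(C(=O)/C=C\Nc2ccc(-c3nc4cc(OC)c(OC)c(OC)c4s3)cc2C)cc1[N+](=O)[O-]` gives 9100 nM
- compound 2 `COc1cc(C(=O)/C=C\Nc2ccc(-c3nc4cc(OC)c(OC)c(OC)c4s3)cc2C)c(Br)c(OC)c1OC` gives 10300 nM

Compound 2 stands level with compound 1, their two values lying within the scatter of each other. Compound 3 `COc1cc(C(=O)/C=C\Nc2ccc(-c3nc4cc(OC)c(OC)c(OC)c4s3)cc2C)cc(OC)c1OC` is still unmeasured. It departs from compound 2 by hydrogen in place of bromo on an aromatic carbon. Among the measured compounds shown here, no step between measured compounds informs this change, so any expectation in this assay is a judgement: a moderate fall in the number is expected, toward stronger inhibition. The expected change is an estimated 3.4-fold lower number from compound 2 to compound 3 (0.54 log units; beyond the scatter). Compound 3 is estimated at 3000 nM (500 nM to 12000 nM).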

Compound 3, half-maximal inhibitory concentration: 23300 nM
The estimate for compound 3 lay 7.8-fold (0.89 log units) below the measured number; measured number outside the range, above it.
By their numbers in this assay, from the lowest: compounds 1 and 2 (each within the scatter of the next); then compound 3.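

In this assay, hydrogen in place of bromo on this aromatic carbon, ortho to a large group, gives a 2.3-fold higher number from compound 2 to compound 3 (0.35 log units; beyond the scatter) and so moves toward weaker inhibition. With 3,4,5-trimethoxyphenyl in place of 4-methoxy-3-nitrophenyl on the carbonyl carbon, the series shows a 2.6-fold higher number from compound 1 to compound 3 (0.41 log units; beyond the scatter) and compound 3 ends as the weakest of the three. No supporting measurement accounts for either step. Open, as far as these compounds go, is whether chloro, fluoro or an amine on the same aromatic carbon would match the bromo of compound 2 or go beyond it.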